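Swapping the Aryl Sulfone for a Hydroxypiperidine Sulfonamide

This account rests on a few compounds, and the source may have more. Where it says the series, first, only, none or still open, it means among the compounds named here.

Measured compounds:
compound 1 `O=C(NCc1ccc(S(=O)(=O)c2ccccc2)cc1)N1Cc2ccncc2C1`: 7.5 mL/min/kg
compound 2 `O=C(NCc1ccc(S(=O)(=O)c2cc(F)cc(F)c2)cc1)N1Cc2ccncc2C1`: 8 mL/min/kg

In an ADME assay on microsomes from liver (Homo sapiens) for pharmacokinetics, read by LC-MS, with a stated time of 60 min, tested at 1 uM (on this read-out lower numbers stand for slow clearance and higher numbers for fast clearance), compound 1 gives 7.5 mL/min/kg, and compound 2 gives 8 mL/min/kg. Where compound 2 stands among the numbers shown is simple: it is one of only two, and the step of a 1.1-fold higher number from compound 1 to compound 2 (0.03 log units; within the scatter) places it within the scatter of compound 1, so the two cannot be told apart.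

Compound 3 `O=C(NCc1ccc(S(=O)(=O)N2CCC(O)CC2)cc1)N1Cc2ccncc2C1` is the next step. Its change from compound 2 is 4-hydroxypiperidin-1-yl in place of 3,5-difluorophenyl on a sulfonyl sulfur.

Within the data shown here, the one measured step, a 1.1-fold higher number from compound 1 to compound 2 (0.03 log units; within the scatter), exchanged one aryl group for another on the sulfonyl sulfur and moved nothing beyond the scatter. Among the measured compounds shown here, no measured step covers the entry of a 4-hydroxypiperidin-1-yl at that position, so the expectation rests on the two low numbers already seen. Compound 3 is therefore expected to give 7 mL/min/kg, with a range from 3.5 mL/min/kg to 14 mL/min/kg. The expected step is a 1.1-fold lower number from compound 2 to compound 3 (0.06 log units; within the scatter), which is not expected to exceed the scatter.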

Compound 3, clearance: 6 mL/min/kg
Compound 3: middle estimate off by 1.2-fold (0.07 log units), on the high side; the measured number falls inside the stated range.
By their numbers in this assay, from the lowest: compounds 3, 1 and 2 (each within the scatter of the next).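

In this assay the sulfonyl sulfur, whose other neighbour is an aromatic carbon, now carries a non-aromatic ring, and the numbers do not separate it from either aryl group: the exchange gives a 1.3-fold lower number from compound 2 to compound 3 (0.12 log units; within the scatter) and, against the unsubstituted aryl group, a 1.3-fold lower number from compound 1 to compound 3 (0.10 log units; within the scatter) in the same read-out. The earlier compounds had shown only one aryl group exchanged for another, whereas this change removes the aromatic ring and brings in 4-hydroxypiperidin-1-yl, with its hetero atom, hydrogen-bond donor and hydrogen-bond acceptor, without a step beyond the scatter. No supporting evidence accounts for this result.

The compounds shown leave open what the hydroxyl contributes, which an unsubstituted piperidine or a morpholine on the same sulfur would address. They also leave open whether a basic amine or a carboxylic acid would be accommodated there.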